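Three aryl variants on one core, and a nitrophenyl newcomer

The source may hold more compounds than are shown below. What is called first, only, known or untested is meant among the compounds shown, and "the series" means these compounds.

Measured so far:
- compound 1 `COc1cccc(-c2cc(-c3cc(C(C)C)c(O)cc3C)[nH]c(=O)c2C#N)c1`: 49%
- compound 2 `Cc1cc(O)c(C(C)C)cc1-c1cc(-c2cccs2)c(C#N)c(=O)[nH]1`: 68%
- compound 3 `COc1ccc(-c2cc(-c3cc(C(C)C)c(O)cc3C)[nH]c(=O)c2C#N)cc1OC`: 61%

All three compounds share the same core and differ only in the aryl group on the carbon ortho to the cyano group. In a functional assay for inhibition, tested at 100 ug/mL (on this read-out higher numbers stand for a stronger effect at the one concentration tested and lower numbers for a weaker effect), compound 3 gives 61%, the second highest of the three numbers; its nearest neighbour is compound 2, and the gap a number 7 percentage points lower from compound 2 to compound 3 (within the scatter) lies within the scatter, while the gap to compound 1, a number 12 percentage points higher from compound 1 to compound 3 (beyond the scatter), lies beyond it.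

Compound 4 `Cc1cc(O)c(C(C)C)cc1-c1cc(-c2ccccc2[N+](=O)[O-])c(C#N)c(=O)[nH]1` is not yet measured. Its change from compound 3 is 2-nitrophenyl in place of 3,4-dimethoxyphenyl on an aromatic carbon. For the measured compounds named here, no measured step swaps in a nitro-bearing ring, so the relevant steps are those that change the aryl group on this same carbon: a number 19 percentage points higher from compound 1 to compound 2 (beyond the scatter) and a number 12 percentage points higher from compound 1 to compound 3 (beyond the scatter) were modest, and a number 7 percentage points lower from compound 2 to compound 3 (within the scatter) was within the scatter. Across these three aryl groups the read-out spans only a modest band, so a step of similar modest size, in either direction or none beyond the scatter, is expected, a number 6 percentage points lower from compound 3 to compound 4 (within the scatter).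

Compound 4 is therefore estimated at 55%, with a range from 35% to 72%.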

Compound 4, a percentage reported as inhibition, at one concentration (the size of the read-out at that concentration, not a potency): 37.5%
Compound 4: the middle estimate sits 17.5 percentage points above what was measured; measured number inside the range.
By their numbers in this assay, from the lowest: compound 4; then compound 1; then compounds 3 and 2 (each within the scatter of the next).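

For the compounds shown here, on the aromatic carbon ortho to a cyano group, 2-nitrophenyl is the first aryl group that reads clearly below all the others in this assay, with a number 23.5 percentage points lower from compound 3 to compound 4 (beyond the scatter) and a number 30.5 percentage points lower from compound 2 to compound 4 (beyond the scatter) and also a number 11.5 percentage points lower from compound 1 to compound 4 (beyond the scatter). Going by these compounds alone, the spread at this carbon is therefore wider than the first three compounds suggested, and the swap from thiophen-2-yl is the only step here printed as large, even though 3,4-dimethoxyphenyl and 2-nitrophenyl both carry one six-membered aromatic ring of carbon only and match in their counts of hydrogen-bond donors and acceptors. Nothing available here bears on why the number falls with this change.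

The compounds shown leave open whether the lower number goes with the nitro group itself or with where it sits on the phenyl ring. They also leave open how an unsubstituted phenyl, an aminophenyl or a carboxyphenyl group would read at this carbon, and whether these differences would hold with another change elsewhere on the shared core.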